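This account rests on a few compounds, and the source may have more. Where it says the series, first, only, none or still open, it means among the compounds named here.

Of the compounds shown here, two of a shared core have been measured. Compound 1, `CCC1=C(O)c2c(oc(-c3ccc(OC(F)(F)F)cc3)cc2=O)C(CC)(CC)C1=O`, gives 9.95 uM in a functional assay on KBVIN cells (Homo sapiens) for antiproliferative activity, read by sulforhodamine B assay, with a stated time of 3 days; a higher number here means that more compound is needed for the effect, a lower number that less compound is needed. Compound 2, `CCC1=C(O)c2c(oc(-c3ccc(CBr)cc3)cc2=O)C(CC)(CC)C1=O`, gives 27.9 uM in the same assay. For the measured compounds named here, the single measured step, a 2.8-fold higher number from compound 1 to compound 2 (0.45 log units; beyond the scatter), is therefore the only comparison available, and on it compound 2 stands at the higher of the two numbers, with compound 1 the nearer and lower one.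

Compound 3, `CCC1=C(O)c2c(oc(-c3ccc(OC)c(Cl)c3)cc2=O)C(CC)(CC)C1=O`, is not yet measured. Its change from compound 2 is 3-chloro-4-methoxyphenyl in place of 4-(bromomethyl)phenyl on an aromatic carbon. Going by the values given here, no measured step bears directly on this exchange: the one known step concerns bromomethyl against trifluoromethoxy, and neither a chloro nor a methoxy group on this phenyl has been measured. Among the compounds with values here, the only guidance is that compound 1, carrying an oxygen-linked group on the phenyl, sits at the lower number, so a number nearer to compound 1 than to compound 2 is expected for compound 3. Compound 3 is estimated at 12 uM, with a range from 4 uM to 35 uM. This estimate implies a step of a 2.3-fold lower number from compound 2 to compound 3 (0.37 log units; beyond the scatter), which is expected to be toward a lower number, though with wide uncertainty.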

Compound 3, concentration for half-maximal effect: 1.37 uM
For compound 3 the middle estimate is 8.8-fold (0.94 log units) above the measured one, outside the stated range (below it).
By their numbers in this assay, from the lowest: compound 3; then compound 1; then compound 2.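

In this assay, placing 3-chloro-4-methoxyphenyl on the aromatic carbon next to the ring oxygen instead of 4-(bromomethyl)phenyl gives a 20-fold lower number from compound 2 to compound 3 (1.31 log units; beyond the scatter), a much larger change than the earlier 2.8-fold higher number from compound 1 to compound 2 (0.45 log units; beyond the scatter). The number at this place of the shared core therefore depends far more strongly on the attached phenyl group than the first two compounds showed, and compound 3 at 1.37 uM has the lowest of the three numbers, with compound 1 at 9.95 uM. The exchange replaces the whole substitution pattern of the phenyl ring at once, so this single step cannot be divided between the chloro group, the methoxy group and the loss of the bromomethyl group.

No evidence is available on what lies behind this large step. As far as these compounds go, it remains open how a 4-methoxyphenyl without the chlorine or a 3-chlorophenyl without the methoxy group would compare, and whether an amine, a carboxylic acid or a longer alkoxy chain on this phenyl ring would keep the number as low as that of compound 3.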